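This account rests on a few compounds, and the source may have more. Where it says the series, first, only, none or still open, it means among the compounds named here.

In a functional assay on BXPC-3 cells (Homo sapiens) for inhibition, read by XTT assay, with a stated time of 72 h (a higher number here means a weaker inhibitor, a lower number a stronger inhibitor), compound 1 `CC(C)(C)OC(=O)N1CCC[C@H]1COCCCCCCCC/C=C/c1ccc(-c2ccccc2)cc1` gives 70000 nM. Compound 2 `CC(C)(C)OC(=O)N1CCC[C@H]1COCCCCCCCC/C=C/c1ccc(Oc2ccccc2)cc1` carries one change against it: phenoxy in place of phenyl on an aromatic carbon. For compound 2 the result in this assay is a limit of the assay, > 100000 nM. That makes the step of an at least 1.4-fold higher number from compound 1 to compound 2 (0.15 log units; that floor lies within the scatter), and the only such reading shown is the limit of > 100000 nM in this assay, at which 1 of the 3 values shown sits. Compound 3 `O=CN1CCC[C@H]1COCCCCCC/C=C/c1ccc(-c2ccccc2)cc1` rests on a different core; the difference between the two cores is not broken down here. In this assay compound 3 gives 53300 nM. Compound 4 `O=CN1CCC[C@H]1COCCCCCC/C=C/c1ccc(Oc2ccccc2)cc1` carries the same change on the core of compound 3: phenoxy in place of phenyl on an aromatic carbon. The step is expected to be a 1.9-fold higher number from compound 3 to compound 4 (0.27 log units; within the scatter), resting on an at least 1.4-fold higher number from compound 1 to compound 2 (0.15 log units; that floor lies within the scatter). Compound 4 is therefore estimated at 100000 nM in this assay, between 50000 nM and 250000 nM.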

Compound 4, half-maximal inhibitory concentration: 46700 nM
Compound 4: middle estimate off by 2.1-fold (0.33 log units), on the high side; measured number outside the range, below it.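

In this assay, phenoxy in place of phenyl on the core of compound 3 gives a 1.1-fold lower number from compound 3 to compound 4 (0.06 log units; within the scatter), a step that stays within the scatter. Set beside the earlier step, this shows only how far the two cores can be compared: the same change on two cores in this assay, an at least 1.4-fold higher number (0.15 log units; that floor lies within the scatter) from compound 1 to compound 2 and a 1.1-fold lower number (0.06 log units; within the scatter) from compound 3 to compound 4; the limit leaves it open whether they differ. On these data alone, compound 2 reads > 100000 nM, which is a limit of the assay and not a number, so the size of the change on the core of compound 1 remains unknown.

The compounds shown leave open how other groups in this place, such as an amine or a carboxylic acid, would read. They also leave open what a longer chain would do on its own, apart from the other differences between the two cores.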